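A few compounds are considered here, and "the series" means these few. Any claim that something is new, unique, unknown or untested is made for them only; others in the source may bear on it.

Compound 1, `N[C@@H](COP(=O)(O)OCCCOC(=O)CCc1ccccc1OCCCCOc1ccccc1)C(=O)O`, and compound 2, `N[C@@H](COP(=O)(O)OCCCOC(=O)CCc1ccccc1OCc1cccc(Oc2cccc(Cl)c2)c1)C(=O)O`, share a core and differ in the group carried on the oxygen of the aromatic ring. In an assay on cells for activation of probable G-protein coupled receptor 34 (Mus musculus), with a stated time of 1 h (a higher number here means a larger maximal response, a lower number a smaller maximal response), compound 1 gives 0.033, whereas compound 2 gives 0.53, the higher of the two numbers, and the gap between them lies beyond the usual scatter. Compound 3, `N[C@@H](COP(=O)(O)OCCCOC(=O)CCc1ccccc1OCc1cccc(Oc2ccc(I)cc2)c1)C(=O)O`, is the next step from compound 2: 4-iodophenyl in place of 3-chlorophenyl on an oxygen on an aromatic ring. Seen one bond further out, the change reads 3-chlorophenoxy to 4-iodophenoxy, with the same count of heavy atoms, a single six-membered aromatic ring of carbon only, and no donors or acceptors on either side. Among the compounds with values here, with no measured pair that isolates such a swap, the expected step in this assay from compound 2 to compound 3 is small and without a clear direction, a number 0.080 lower from compound 2 to compound 3 (within the scatter), that is, within the scatter. Compound 3 is therefore estimated at 0.45, with a range from 0.2 to 0.8.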

Compound 3, intrinsic activity: the largest response reached, as a fraction of the reference agonist's: 0.82
Compound 3: middle estimate off by 0.37, on the low side; measured number above the stated range.
By their numbers in this assay, from the lowest: compound 1; then compound 2; then compound 3.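

On an oxygen on an aromatic ring, the terminal group matters to the maximal response: in this assay, 4-iodophenyl in place of 3-chlorophenyl gives a number 0.29 higher from compound 2 to compound 3 (beyond the scatter). The two groups match in heavy-atom count, in their single six-membered aromatic ring of carbon only, and in having no hydrogen-bond donors or acceptors, so these counts alone do not set the response at this place. Nothing available explains the step.

This one swap changes both the halogen and its number on the ring, so the compounds shown cannot say which of the two carries the step. 4-Chlorophenyl and 3-iodophenyl would separate them, while an amine or a carboxylic acid on the same ring would test whether a halogen is needed at all.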